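Cyclopentyloxy-methoxy benzamides: varying the amide nitrogen substituent

This account rests on a few compounds, and the source may have more. Where it says the series, first, only, none or still open, it means among the compounds named here.

Measured so far in an assay on isolated protein for inhibition of phosphodiesterase 4A (Sus scrofa); on this read-out lower numbers stand for stronger inhibition and higher numbers for weaker inhibition:
- compound 1, `COc1ccc(C(=O)Nc2ccccc2SC)cc1OC1CCCC1`: 1200 nM
- compound 2, `COc1ccc(C(=O)Nc2ccncc2)cc1OC1CCCC1`: 800 nM

Compound 2 has the lowest of the two numbers in this assay, though the step of a 1.5-fold lower number from compound 1 to compound 2 (0.18 log units; within the scatter) means compound 2 and compound 1 cannot be ranked against each other on this read-out.

Compound 3, `COc1ccc(C(=O)Nc2c(Br)cncc2Br)cc1OC1CCCC1`, differs from compound 2 only at the amide-type nitrogen: 3,5-dibromopyridin-4-yl in place of pyridin-4-yl on an amide-type nitrogen. Among the measured compounds shown here, the one measured step touching that nitrogen, a 1.5-fold lower number from compound 1 to compound 2 (0.18 log units; within the scatter), exchanged the whole substituent and moved the number only within the scatter. For the measured compounds named here, no measured step adds bromine to a ring that is otherwise kept, so the present change has no direct precedent. Going by the values given here, the pyridin-4-yl of compound 2 is retained and two bromines enter; the expectation is a drop in the number, an 8.0-fold lower number from compound 2 to compound 3 (0.90 log units; beyond the scatter), but with a wide range because the sole step a 1.5-fold lower number from compound 1 to compound 2 (0.18 log units; within the scatter) gives no guide to the size. Compound 3 is therefore estimated at 100 nM, within 8 nM to 1200 nM.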

Compound 3, half-maximal inhibitory concentration: 7 nM
Compound 3: middle estimate off by 14-fold (1.15 log units), on the high side, outside the stated range (below it).
By their numbers in this assay, from the lowest: compound 3; then compounds 2 and 1 (each within the scatter of the next).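

In this assay the substituent on the amide-type nitrogen proves able to move the number far beyond the scatter, which compound 1 and compound 2 did not show: the change gives a 110-fold lower number from compound 2 to compound 3 (2.06 log units; beyond the scatter) and the wider exchange gives a 170-fold lower number from compound 1 to compound 3 (2.23 log units; beyond the scatter) on the same substituent. With the pyridin-4-yl kept, the entry of the two bromines alone accounts for the large step, so this position responds to substitution on a retained ring and not only to exchange of the whole group. No measurement bearing on the origin of this step is available.

The compounds shown leave open whether a single bromine, as in 3-bromopyridin-4-yl, carries the step, or whether chlorine or methyl can stand in place of bromine. They also leave open what 3,5-dibromophenyl, with carbon in place of the ring nitrogen, would give.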